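Fluoro in place of methyl on an aromatic carbon

A few compounds are considered here, and "the series" means these few. Any claim that something is new, unique, unknown or untested is made for them only; others in the source may bear on it.

In a functional assay on PC-3 cells (Homo sapiens) for cytotoxicity, read by sulforhodamine B assay, with a stated time of 48 h (a higher number here means a weaker inhibitor, a lower number a stronger inhibitor), compound 1 (`COc1ccc(C2=NO[C@]3(C2)C(=O)O[C@@H]2[C@H]3CC[C@H](C)[C@]3(O)C=CC(=O)[C@@]23C)cc1`) gives 35000 nM while compound 2 (`Cc1ccccc1C1=NO[C@]2(C1)C(=O)O[C@@H]1[C@H]2CC[C@H](C)[C@]2(O)C=CC(=O)[C@@]12C`) gives 10000 nM and compound 3 (`Cc1ccc(C2=NO[C@]3(C2)C(=O)O[C@@H]2[C@H]3CC[C@H](C)[C@]3(O)C=CC(=O)[C@@]23C)cc1`) gives 14000 nM in the same test. One step among these values lies within the scatter (a 1.4-fold higher number from compound 2 to compound 3 (0.15 log units; within the scatter)) and another lies beyond it (a 2.5-fold lower number from compound 1 to compound 3 (0.40 log units; beyond the scatter)). Compound 4 (`C[C@H]1CC[C@@H]2[C@@H](OC(=O)[C@]23CC(c2ccc(F)cc2)=NO3)[C@]2(C)C(=O)C=C[C@@]12O`) differs from compound 3 at one place (fluoro in place of methyl on an aromatic carbon), with fluoro in place of methyl on an aromatic carbon, para to a large group. Going by the values given here, the only measured change on that carbon, methyl in place of methoxy, was the modest step from compound 1, and no measured compound carries fluoro. A step within the scatter is therefore expected in this assay (a 1.1-fold higher number from compound 3 to compound 4 (0.03 log units; within the scatter)) for this swap. Compound 4 is estimated at 15000 nM with an expected range from 7000 nM to 32000 nM in this test.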

Compound 4, half-maximal inhibitory concentration: 27000 nM
For compound 4 the middle estimate is 1.8-fold (0.26 log units) below the measured one; measured number inside the range.
By their numbers in this assay, from the lowest: compounds 2, 3, 4 and 1 (each within the scatter of the next, the first and the last beyond it).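

In this assay fluoro on this aromatic carbon stays within the scatter of methyl (a 1.9-fold higher number from compound 3 to compound 4 (0.29 log units; within the scatter)) and also of methoxy (a 1.3-fold lower number from compound 1 to compound 4 (0.11 log units; within the scatter)). Fluoro therefore cannot be told apart from either group here, even though methyl and methoxy differ by a step beyond the scatter. Among the compounds compared, only the 2-methylphenyl compound stands clear of the 4-fluorophenyl one (a 2.7-fold higher number from compound 2 to compound 4 (0.43 log units; beyond the scatter)). Nothing available explains these numbers. From the compounds shown here alone, whether an amine or a carboxylic acid on this carbon would shift the number further remains open.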